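The compounds below may be only part of what the source reports. "The series", "measured", "known", "first", "only" and "open" are said of these compounds alone.

In an ADME assay on microsomes from liver (Homo sapiens) for metabolic stability, read by LC-MS, with a stated time of 30 min, tested at 0.5 uM (on this read-out lower numbers stand for a less stable compound and higher numbers for a more stable compound), compound 3 `Oc1cccc(-c2nc(-c3csc(N=C4NCCCN4)n3)cs2)c1` gives 77% and compound 1 `c1ccc(-c2cc(-c3csc(N=C4NCCCN4)n3)cs2)cc1` gives 70%, two values within the scatter of each other. Compound 2 `c1ccc(-n2ccc(-c3csc(N=C4NCCCN4)n3)n2)cc1` gives 38%, which lies beyond the scatter below compound 3. Compound 4 `c1cncc(-c2nc(-c3csc(N=C4NCCCN4)n3)cs2)c1` keeps the shared core of compound 3 but carries pyridin-3-yl in place of 3-hydroxyphenyl on an aromatic carbon. For the measured compounds named here, no measured pair of compounds isolates a change in one place, so the size of this step in this assay cannot be read from the data, and no step beyond the scatter is expected. The estimated change is a number 5 percentage points lower from compound 3 to compound 4 (within the scatter), a small fall. For compound 4 the estimated value is 72%, with an expected range from 50% to 90%.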

Compound 4, percent of the compound remaining: 78%
The estimate for compound 4 lay 6 percentage points below the measured number, and the stated range covers the measured number.
By their numbers in this assay, from the lowest: compound 2; then compounds 1, 3 and 4 (each within the scatter of the next).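

In this assay, for the compounds shown here, swapping 3-hydroxyphenyl for pyridin-3-yl on this aromatic carbon gives the first step that isolates a change in one place: a number 1 percentage points higher from compound 3 to compound 4 (within the scatter). The hydrogen-bond donor of 3-hydroxyphenyl can therefore be absent from this position with no step beyond the scatter, at least for this pair. Nothing available explains this outcome. The compounds shown leave open whether the read-out would stay within the scatter with a carboxylic acid or an amine on the ring at this position. They also leave open whether a non-aromatic group, such as a longer alkyl chain, would do the same.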